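The source may report more compounds than this note shows. Statements on the series, on what has been measured and on what is new or still open speak of the compounds shown alone.

Notes on the series. Of the compounds shown here, three sharing a common core have been measured in a functional assay on MDA-MB-231 cells (Homo sapiens) for cytotoxicity, read by MTT assay, with a stated time of 48 h; a higher number here means a weaker inhibitor, a lower number a stronger inhibitor. Compound 1 `O=C(/C=C/c1ccc2c(c1)B(O)OC2)c1ccc(F)cc1` gives 1600 nM; compound 2 `O=C(/C=C/c1ccc2c(c1)B(O)OC2)c1ccc(Cl)cc1` gives 7900 nM; compound 3 `Cc1cccc(C(=O)/C=C/c2ccc3c(c2)B(O)OC3)c1` gives 4500 nM. Compound 3 thus holds the second highest number of the three: its nearest neighbour is compound 2, whose number is within the scatter of it, and its furthest is compound 1, whose number lies below it beyond the scatter. For the measured compounds named here, the two steps that replaced the aryl group on the carbonyl carbon, a 2.8-fold higher number from compound 1 to compound 3 (0.45 log units; beyond the scatter) and a 1.8-fold lower number from compound 2 to compound 3 (0.24 log units; within the scatter), are the only guide to what a change at that position does; the step of a 4.9-fold higher number from compound 1 to compound 2 (0.69 log units; beyond the scatter) concerns a halogen swap on that same ring and shows that even a small change there can move the number beyond the scatter.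

Compound 4 `O=C(/C=C/c1ccc2c(c1)B(O)OC2)c1ccccc1O` is not yet measured. It differs from compound 3 by 2-hydroxyphenyl in place of 3-methylphenyl on a carbonyl carbon. Going by the values given here, no measured compound carries a hydroxyl on this ring, so no step speaks directly to it. Judged on the two aryl swaps seen so far, the step from compound 3 to compound 4 is expected to be modest, with its direction open: a 1.1-fold lower number from compound 3 to compound 4 (0.05 log units; within the scatter). For compound 4 in this assay a value of 4000 nM is estimated, within a range of 1500 nM to 12000 nM.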

Compound 4, half-maximal inhibitory concentration: 16900 nM
For compound 4 the middle estimate is 4.2-fold (0.63 log units) below the measured one; the measured number lies above the stated range.
By their numbers in this assay, from the lowest: compound 1; then compounds 3 and 2 (each within the scatter of the next); then compound 4.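

Notes on the result. In this assay, for the compounds shown here, the aryl group on the carbonyl carbon moves the number further than the first three compounds showed, with a 3.8-fold higher number from compound 3 to compound 4 (0.57 log units; beyond the scatter) and a 2.1-fold higher number from compound 2 to compound 4 (0.33 log units; beyond the scatter) as the smaller steps and an 11-fold higher number from compound 1 to compound 4 (1.02 log units; beyond the scatter) as the largest, the only step called large. Going by these compounds alone, compound 4 is therefore the weakest of the four, since all of its steps are printed as beyond the scatter, and the earlier aryl swaps gave no sign of a step of this reach from the compound 1 end of the series. The swap from 3-methylphenyl to 2-hydroxyphenyl leaves the ring type and the heavy-atom count unchanged and still shifts the number beyond the scatter, so at this position these two counts do not settle the outcome.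

No measurement at hand accounts for the shift. Still open, going by these compounds, is whether the hydroxyl itself or its ring position carries the change, a question that plain phenyl, 2-methoxyphenyl and 2-aminophenyl on the carbonyl carbon would bear on.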